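Aryl exchange on the fused core: compound 3

The source may hold more compounds than are shown below. What is called first, only, known or untested is meant among the compounds shown, and "the series" means these compounds.

Measured so far in a functional assay on the whole organism (strain Wistar albino) for inhibition, with Rattus norvegicus as the target, read by paw edema, with stated times of 30 min and 1.5 h, at a dose of 20 mg/kg by the oral route; on this read-out lower numbers stand for less inhibition and higher numbers for more inhibition at the one dose given (going by the name of the read-out):
compound 1 `Cc1nn2c(C(C)c3ccc(CC(C)C)cc3)nnc2s1` gives 62%
compound 2 `CC(C)Cc1ccc(C(C)c2nnc3sc(-c4ccc(Br)cc4)nn23)cc1` gives 69%

Of the two numbers shown, that of compound 2 is the larger, but a number 7 percentage points higher from compound 1 to compound 2 (within the scatter) lies within the scatter, so the two compounds are not separated by this assay.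

Compound 3 `CC(C)Cc1ccc(C(C)c2nnc3sc(-c4ccc([N+](=O)[O-])cc4Cl)nn23)cc1` differs from compound 2 in one place: 2-chloro-4-nitrophenyl in place of 4-bromophenyl on an aromatic carbon. The single measured step, a number 7 percentage points higher from compound 1 to compound 2 (within the scatter), sits at the same position of the shared core but exchanges methyl for an aryl group; no measured step exchanges one aryl group for another, so nothing shown bears directly on the change to compound 3. Within the data shown here, with only that small step as a guide, no movement beyond the scatter is expected, and a number 1 percentage points lower from compound 2 to compound 3 (within the scatter) is the estimated step. Compound 3 is therefore expected to give about 68% in this assay, with a range from 54% to 82%.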

Compound 3, a percentage reported as inhibition, in the whole organism at one dose (the size of the read-out at that dose, not a potency): 59%
Compound 3: the middle estimate sits 9 percentage points above what was measured; the measured number falls inside the stated range.
By their numbers in this assay, from the lowest: compounds 3, 1 and 2 (each within the scatter of the next).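

In this assay, the exchange of one aryl group for another at this aromatic carbon now has a measured step, a number 10 percentage points lower from compound 2 to compound 3 (within the scatter), and 2-chloro-4-nitrophenyl is not separated from 4-bromophenyl despite its larger size in heavy atoms and its 2 hydrogen-bond acceptors. Against methyl at the same position the step is a number 3 percentage points lower from compound 1 to compound 3 (within the scatter), so methyl, 4-bromophenyl and 2-chloro-4-nitrophenyl all remain unresolved from one another on this read-out. No measurement bears on the reason for this result.

The compounds shown do not separate any contribution of the chlorine from that of the nitro group, since both enter together. Also open, as far as these compounds go, is whether a group of another kind at this carbon, such as an amine, a carboxylic acid or a longer chain, would move the number beyond the scatter.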